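The source may report more compounds than this note shows. Statements on the series, on what has been measured and on what is new or still open speak of the compounds shown alone.

Measured in a functional assay on the whole organism for agonist activity, with Mus musculus as the target; on this read-out higher numbers stand for an effect only at larger amounts of compound and lower numbers for an effect already at smaller amounts:
- compound 1 `CC(C#CCn1ccnc1)N1CCCC1=O`: > 100 mg/kg (a limit)
- compound 2 `CC(=O)NCC#CCn1cncc1C`: 66 mg/kg
- compound 3 `COC(=O)NCC#CCn1cncc1C`: > 100 mg/kg (a limit)

Compound 3 gives no number, only the limit > 100 mg/kg. Compound 3 thus sits at the limit of > 100 mg/kg in this assay, at which 2 of the 3 values shown sit.

Compound 4 `COC(=O)N(C)CC#CCn1cncc1C` carries methyl in place of hydrogen on an amide-type nitrogen. For the measured compounds named here, only one measured step is available as a guide, and it lies at a different place: an at least 1.5-fold higher number from compound 2 to compound 3 (0.18 log units; that floor lies within the scatter), with methoxy in place of methyl on a carbonyl carbon. Going by the values given here, it is known only as a floor within the scatter, and no measured step involves the amide-type nitrogen. No step beyond the scatter is therefore expected in this assay, in either direction, and this expectation rests on thin data. The estimated step is a step that the limit leaves unreadable from compound 3 to compound 4. Another limit is the more likely report. For compound 4 the expected value is 110 mg/kg, with an estimated range of 50 mg/kg to 240 mg/kg.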

Compound 4, dose for half-maximal effect: > 100 mg/kg
Compound 4: a limit, no number; the forecaster's own chance of this, stated with the estimate: 65%; the middle value does not contradict the limit.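

No step can be read from compound 3 to compound 4 in this assay, because both compounds give only a limit: the limit of > 100 mg/kg in this assay, at which 3 of the 4 values shown sit. The compounds shown leave open whether methyl in place of hydrogen on the amide-type nitrogen changes the read-out at all, in either direction.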